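Working notes: compound 3 to compound 4

A few compounds are considered here, and "the series" means these few. Any claim that something is new, unique, unknown or untested is made for them only; others in the source may bear on it.

compound 1 `CCCCc1ccc2[nH]c(-c3ccc(OC)cc3)c(/C=N/NC(=O)c3ccccc3)c2c1` gives 32 nM
compound 2 `CCCCc1ccc2[nH]c(-c3ccc(OC)cc3)c(/C=N/NC(=O)c3ccc([N+](=O)[O-])cc3)c2c1` gives 115 nM
compound 3 `CCCCc1ccc2[nH]c(-c3ccc(OC)cc3)c(/C=N/NC(=O)c3ccncc3)c2c1` gives 29 nM

All three numbers come from a functional assay on MDA-MB-231 cells (Homo sapiens) for antiproliferative activity, with a stated time of 4 days (on this read-out lower numbers stand for stronger inhibition and higher numbers for weaker inhibition), as the only read-out. Compound 3 sits with compound 1 at the low end of these numbers, the two within the scatter of each other, while compound 2 stands clearly apart. Compound 4 `CCCCc1ccc2[nH]c(-c3ccc(OC)cc3)c(/C=N/NC(=O)c3ccccn3)c2c1` carries pyridin-2-yl in place of pyridin-4-yl on a carbonyl carbon with the rest unchanged. Swapping phenyl for pyridin-4-yl at this place gave a 1.1-fold lower number from compound 1 to compound 3 (0.04 log units; within the scatter) and so moved nothing measurable. Only the nitro compound departs, with a 3.6-fold higher number from compound 1 to compound 2 (0.56 log units; beyond the scatter) and a 4.0-fold lower number from compound 2 to compound 3 (0.60 log units; beyond the scatter) as its two steps. Among the compounds with values here, no measured compound carries pyridin-2-yl, so the guide is indirect. The expected step is a 1.2-fold higher number from compound 3 to compound 4 (0.08 log units; within the scatter) and no change beyond the scatter is anticipated. For compound 4 the estimate is 35 nM with an expected range from 13 nM to 95 nM in this assay as read here.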

Compound 4, half-maximal inhibitory concentration: 34 nM
For compound 4 the middle estimate is 1.0-fold (0.01 log units) above the measured one, within the range that was stated.
By their numbers in this assay, from the lowest: compounds 3, 1 and 4 (each within the scatter of the next); then compound 2.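

In this assay, pyridin-2-yl in place of pyridin-4-yl on a carbonyl carbon gives a 1.2-fold higher number from compound 3 to compound 4 (0.07 log units; within the scatter), so the placing of the ring nitrogen in these two pyridines does not separate them. Pyridin-2-yl in place of phenyl also stays within the scatter, with a 1.1-fold higher number from compound 1 to compound 4 (0.03 log units; within the scatter), while pyridin-2-yl in place of 4-nitrophenyl gives a 3.4-fold lower number from compound 2 to compound 4 (0.53 log units; beyond the scatter), so the nitro compound still stands apart. Nothing available explains these steps.

Still open, going by these compounds, is whether pyridin-3-yl at this place would match these values. Also open, on these data alone, is whether an amine or a carboxylic acid in place of the nitro would give a comparable step.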